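Shortening the linker and moving the halogen in a sulfonamide series

The source may report more compounds than this note shows. Statements on the series, on what has been measured and on what is new or still open speak of the compounds shown alone.

The set rests on a shared core that carries a fluorophenyl-bearing fused ring system and a chain-linked aryl group. Compound 1 `O=S(=O)(NCCCNc1nccc(-c2c(-c3cccc(F)c3)nc3sccn23)n1)c1ccc(Br)cc1` gives 7040 nM in a functional assay on A-375 cells (Homo sapiens) for cytotoxicity, read by MTT assay; on this read-out higher numbers stand for weaker inhibition and lower numbers for stronger inhibition. Compound 2 `O=C(NCCNc1nccc(-c2c(-c3cccc(F)c3)nc3sccn23)n1)c1c(F)cccc1F` gives 2700 nM. Compound 3 `O=S(=O)(NCCCNc1nccc(-c2c(-c3cccc(F)c3)nc3sccn23)n1)c1ccc(Cl)cc1` gives 5900 nM, the second highest of the three numbers.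

Compound 4 `O=S(=O)(NCCNc1nccc(-c2c(-c3cccc(F)c3)nc3sccn23)n1)c1cccc(F)c1` differs from compound 3 by ((3-fluorophenyl)sulfonyl)amino in place of (((4-chlorophenyl)sulfonyl)amino)methyl on a saturated chain carbon, two bonds along the chain from a nitrogen on an aromatic ring. Among the measured compounds shown here, two measured steps bear on this. The swap of chloro for bromo on the aromatic carbon, a 1.2-fold lower number from compound 1 to compound 3 (0.08 log units; within the scatter), shows that a halogen change on that ring matters little. The step of a 2.2-fold higher number from compound 2 to compound 3 (0.34 log units; beyond the scatter) combines a shorter chain with a carbonyl in place of the sulfonyl, so it only loosely informs the shortening alone. Compound 4 keeps the sulfonyl and shortens the chain, so a modest move toward a lower number or none beyond the scatter is expected, estimated as a 1.3-fold lower number from compound 3 to compound 4 (0.12 log units; within the scatter). Compound 4 is therefore expected to give about 4500 nM in this assay, within a range from 1800 nM to 11000 nM.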

Compound 4, half-maximal inhibitory concentration: 14900 nM
Compound 4: the middle estimate sits 3.3-fold (0.52 log units) below what was measured; measured number outside the range, above it.
By their numbers in this assay, from the lowest: compound 2; then compounds 3 and 1 (each within the scatter of the next); then compound 4.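

In this assay the step of a 2.5-fold higher number from compound 3 to compound 4 (0.40 log units; beyond the scatter) and the step of a 2.1-fold higher number from compound 1 to compound 4 (0.33 log units; beyond the scatter) both lie beyond the scatter, so replacing either halogenated group at this chain carbon with ((3-fluorophenyl)sulfonyl)amino does move the number, upward, although the swap of chloro for bromo did not. The step of a 5.5-fold higher number from compound 2 to compound 4 (0.74 log units; beyond the scatter) is the largest shown and the first to change only the group on the amine nitrogen, with (3-fluorophenyl)sulfonyl in place of (2,6-difluorophenyl)carbonyl, which leaves compound 4 the weakest of the four. Nothing given here accounts for these steps.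

Compounds 3 and 4 differ in both the chain and the ring halogen, so the share of each in that step stays unresolved. As far as these compounds go, how an amine or a longer chain would read at this place also remains open.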